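Changing the Ester Chain of Compound 2

A few compounds are considered here, and "the series" means these few. Any claim that something is new, unique, unknown or untested is made for them only; others in the source may bear on it.

Measured in an ADME assay on HepG2 2.2.15 cells (Homo sapiens) for cytotoxicity; on this read-out lower numbers stand for higher toxicity in this test and higher numbers for lower toxicity in this test:
Compound 1 `O=c1c(CCO)c(-c2ccccc2Cl)c2cc(Cl)ccc2n1-c1ccccc1`: 26000 nM
Compound 2 `CCCCC(=O)OCCc1c(-c2ccccc2Cl)c2cc(Cl)ccc2[nH]c1=O`: 200000 nM
Compound 3 `CC(=O)NCC(=O)OCCc1c(-c2ccccc2Cl)c2cc(Cl)ccc2[nH]c1=O`: 110000 nM

Compound 2 stands at the upper end of these numbers, level within the scatter with compound 3, while compound 1 lies lower, beyond the scatter. The next compound, compound 4 `O=C(OCCc1c(-c2ccccc2Cl)c2cc(Cl)ccc2[nH]c1=O)C1CCCC1`, differs from compound 2 in one place: cyclopentyl in place of butyl on a carbonyl carbon. In words, cyclopentyl replaces butyl on a carbonyl carbon. The closest measured change is a 1.8-fold lower number from compound 2 to compound 3 (0.26 log units; within the scatter), so it stays within the scatter. Among the compounds with values here, only this one step bears on the change, and no shift beyond the scatter is expected in this assay. The estimated change is a 1.2-fold lower number from compound 2 to compound 4 (0.07 log units; within the scatter). For compound 4 the expected value is 170000 nM, with an estimated range of 70000 nM to 350000 nM.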

Compound 4, half-maximal cytotoxic concentration: 46000 nM
Estimate against measurement, compound 4: 3.7-fold (0.57 log units) above, outside the stated range (below it).
By their numbers in this assay, from the lowest: compounds 1 and 4 (each within the scatter of the next); then compounds 3 and 2 (each within the scatter of the next).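

On this carbonyl carbon, swapping one open chain for another had stayed within the scatter, but a ring goes further in this assay and gives a 4.3-fold lower number from compound 2 to compound 4 (0.64 log units; beyond the scatter) and also a 2.4-fold lower number from compound 3 to compound 4 (0.38 log units; beyond the scatter) as modest shifts towards higher toxicity in this test. Both steps lie beyond the scatter, so the cyclopentyl compound 4 separates from both open-chain esters. Nothing measured here gives a reason for this shift.

With only one ring shown, the effect of closing the ring cannot be separated from that of the extra carbon. On these data alone, whether cyclopropyl, cyclohexyl or a branched isopropyl group would lower the number in the same way also remains open.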